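This account rests on a few compounds, and the source may have more. Where it says the series, first, only, none or still open, it means among the compounds named here.

In a functional assay on HT-1080 cells (Homo sapiens), read by luminescence, with a stated time of 24 h (a lower number here means that less compound is needed, a higher number that more compound is needed for the effect), compound 3 `CC1(C)CC(NC(=O)C(/C=C/[C@@H](NC(=O)OC(C)(C)C)c2ccoc2)(Cc2ccc(F)cc2)Cc2ccc(F)cc2)CC(C)(C)N1` gives 430 nM, the top of the three numbers reported, although it sits within the scatter of both others: compound 1 `CC1(C)CC(NC(=O)C(/C=C/[C@@H](NC(=O)OC(C)(C)C)c2ccc(F)cc2)(Cc2ccc(F)cc2)Cc2ccc(F)cc2)CC(C)(C)N1` gives 280 nM and compound 2 `CC1(C)CC(NC(=O)C(/C=C/[C@H](NC(=O)OC(C)(C)C)c2ccc(F)cc2)(Cc2ccc(F)cc2)Cc2ccc(F)cc2)CC(C)(C)N1` gives 340 nM. Compound 4 `CC1(C)CC(NC(=O)C(/C=C/[C@H](NC(=O)OC(C)(C)C)c2ccoc2)(Cc2ccc(F)cc2)Cc2ccc(F)cc2)CC(C)(C)N1` is related to compound 3 in that (the two compounds have the same atoms and bonds and differ only in configuration as drawn: 1 of 2 stereo elements differ; a stereocentre at a saturated chain carbon is drawn R in compound 3 and S in compound 4). Among the measured compounds shown here, only one measured step bears on this pair, namely a 1.2-fold higher number from compound 1 to compound 2 (0.08 log units; within the scatter), and because of the fact that compounds 1 and 2 differ only in the configuration as drawn that step is the direct parallel to the present one. Carried over, the expected step of no change at the digits printed from compound 3 to compound 4 (within the scatter) amounts to no shift beyond the scatter in either direction. Compound 4 is therefore estimated at 430 nM in this assay, with a range from 200 nM to 900 nM.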

Compound 4, half-maximal effective concentration: 240 nM
Beside the measured number, compound 4's estimate is 1.8-fold (0.25 log units) above it; the range from low to high includes it.
By their numbers in this assay, from the lowest: compounds 4, 1, 2 and 3 (each within the scatter of the next).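

In this assay, the drawn configuration at this saturated chain carbon also stays within the scatter with furan-3-yl on it, as shown by a 1.8-fold lower number from compound 3 to compound 4 (0.25 log units; within the scatter). The replacement of 4-fluorophenyl by furan-3-yl on the S-drawn compounds likewise gives a 1.4-fold lower number from compound 2 to compound 4 (0.15 log units; within the scatter). This replacement has now been read on both drawn configurations, and the two steps do not differ beyond the scatter: the same change on two cores in this assay, a 1.5-fold higher number (0.19 log units; within the scatter) from compound 1 to compound 3 and a 1.4-fold lower number (0.15 log units; within the scatter) from compound 2 to compound 4, 2.2-fold (0.34 log units) apart, within the scatter of two such steps.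

On these data alone, whether an amine or a carboxylic acid in place of furan-3-yl on this carbon would give a step beyond the scatter remains open.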